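Ether side chain and microsomal stability: notes on compound 4

The compounds below may be only part of what the source reports. "The series", "measured", "known", "first", "only" and "open" are said of these compounds alone.

Compound 1, `C[C@H](Nc1ccc(C#N)n(C)c1=O)c1cc2cc(Cl)c(OCC3CC3)cc2[nH]c1=O`, gives 82% in an ADME assay on microsomes from liver (Homo sapiens) for metabolic stability, with a stated time of 30 min; on this read-out lower numbers stand for a less stable compound and higher numbers for a more stable compound.
Compound 2, `C[C@H](Nc1ccc(C#N)n(C)c1=O)c1cc2cc(Cl)c(F)cc2[nH]c1=O`, gives 100% in this assay.
Compound 3, `C[C@H](Nc1ccc(C#N)n(C)c1=O)c1cc2cc(Cl)c(OCc3ccccn3)cc2[nH]c1=O`, gives 66% in this assay.

Compound 3 stands lowest of the three measured numbers in this assay: compound 1 lies nearest, and compound 2 furthest, both beyond the scatter. Among the measured compounds shown here, the steps so far all concern the substituent on the aromatic carbon: a number 18 percentage points higher from compound 1 to compound 2 (beyond the scatter), a number 16 percentage points lower from compound 1 to compound 3 (beyond the scatter) and a number 34 percentage points lower from compound 2 to compound 3 (beyond the scatter).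

Compound 4, `C[C@H](Nc1ccc(C#N)n(C)c1=O)c1cc2cc(Cl)c(O[C@H](C)c3ccccn3)cc2[nH]c1=O`, differs from compound 3 by methyl in place of hydrogen on a saturated chain carbon bound to an aromatic carbon and an oxygen on an aromatic ring. For the measured compounds named here, none of the measured steps bears directly on this change: each of them exchanges the whole substituent on the aromatic carbon, whereas here the (pyridin-2-yl)methoxy group is kept and only a methyl is added on the saturated chain carbon. The measured steps show that changes at this part of the molecule can move the read-out in this assay by modest to large amounts, but they give no direction for a methyl added at this carbon. The expectation is therefore for compound 4 a value close to that of compound 3, with a step of a number 1 percentage points lower from compound 3 to compound 4 (within the scatter) that is not expected to exceed the scatter.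

Compound 4 is estimated at 65% in this assay, within a range from 47% to 83%.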

Compound 4, percent of the compound remaining: 70%
Estimate against measurement, compound 4: 5 percentage points below; low and high end bracket the measured number.
By their numbers in this assay, from the lowest: compounds 3 and 4 (each within the scatter of the next); then compound 1; then compound 2.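

In this assay, methyl in place of hydrogen on the saturated chain carbon of the (pyridin-2-yl)methoxy group gives a step within the scatter (a number 4 percentage points higher from compound 3 to compound 4 (within the scatter)), so in this one pair the added methyl does not separate the two compounds. The 1-(pyridin-2-yl)ethoxy group also keeps the standing that the (pyridin-2-yl)methoxy group had against the other two substituents on the aromatic carbon, with both steps beyond the scatter (a number 12 percentage points lower from compound 1 to compound 4 (beyond the scatter); a number 30 percentage points lower from compound 2 to compound 4 (beyond the scatter)). No measurement at hand offers an explanation for these steps.

As far as these compounds go, this single pair covers only one methyl in one spatial arrangement, so it remains open whether the opposite configuration at this carbon, or an ethyl or a hydroxymethyl group in place of the methyl, would also stay within the scatter of compound 3. From the compounds shown here alone, it also remains open whether a methyl on the matching chain carbon of the cyclopropylmethoxy group of compound 1 would leave the read-out as little changed, or whether a dimethylamino group on the pyridine would shift it.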